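Thiocarbamate Benzamides on Gastric Cancer Cells: Replacing the Aminopyridine

The compounds below may be only part of what the source reports. "The series", "measured", "known", "first", "only" and "open" are said of these compounds alone.

Measured compounds in a functional assay on MGC-803 cells (Homo sapiens) for antiproliferative activity, read by CCK-8 assay, with a stated time of 72 h, tested at 2 uM; on this read-out lower numbers stand for a weaker effect and higher numbers for a stronger effect at the one concentration tested:
- compound 1, `CN(C(=S)SCc1ccc(C(=O)Nc2ccccc2N)cc1)c1cccnc1`, gives 46.1%
- compound 2, `COc1ccc(N2CCN(C(=S)SCc3ccc(C(=O)Nc4ccccc4N)cc3)CC2)cc1`, gives 25.3%
- compound 3, `Nc1ccccc1NC(=O)c1ccc(CSC(=S)N(Cc2ccccc2)Cc2ccccc2)cc1`, gives 11%

Of the three measured compounds, compound 1 stands highest in this assay. Its nearest neighbour is compound 2, whose number lies beyond the scatter below it, and compound 3 lies further below still, also beyond the scatter. All three share the same core and differ only in the amine attached to the thiocarbonyl carbon.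

Compound 4, `Nc1ccccc1NC(=O)c1ccc(CSC(=S)N2CCCC2)cc1`, has not yet been measured in this assay. It differs from compound 1 in one place: pyrrolidin-1-yl in place of methyl(pyridin-3-yl)amino on a thiocarbonyl carbon. Within the data shown here, no step between two measured compounds isolates this change, so the expectation rests on the three values shown. The two measured compounds with an amine other than that of compound 1 both give weaker numbers, yet neither resembles the pyrrolidin-1-yl group closely, so the direction is uncertain. The step is expected to be downward, of a size near the edge of the scatter, a number 14.1 percentage points lower from compound 1 to compound 4 (beyond the scatter). Compound 4 is therefore expected to give about 32%, within a range from 12% to 52%.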

Compound 4, a percentage reported as inhibition, at one concentration (the size of the read-out at that concentration, not a potency): 27%
Compound 4: middle estimate off by 5 percentage points, on the high side, within the range that was stated.
By their numbers in this assay, from the lowest: compound 3; then compounds 2 and 4 (each within the scatter of the next); then compound 1.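

In this assay, among these compounds, the exchange of methyl(pyridin-3-yl)amino for pyrrolidin-1-yl on a thiocarbonyl carbon gives the first step that can be read at this position, a number 19.1 percentage points lower from compound 1 to compound 4 (beyond the scatter). Among the compounds shown here, the change replaces a six-membered aromatic ring with 1 hetero atom by a five-membered non-aromatic ring with 1 hetero atom, and the hydrogen-bond acceptor counted on the leaving group has no counterpart on the entering one, so the step shows that this compact ring amine does not hold the number of compound 1 at this position. Nothing measured here gives a reason for the step, so the data tie it to no particular feature of either group.

Going by these compounds, whether the step follows from the pyridine ring nitrogen, the aromatic ring itself or the methyl on the amine remains open, since the change alters all of these at once. A methyl(phenyl)amino group would set the ring nitrogen apart from the rest of the leaving group, and a dimethylamino or morpholin-4-yl group would extend the comparison beyond the amines shown.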